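The source may hold more compounds than are shown below. What is called first, only, known or untested is meant among the compounds shown, and "the series" means these compounds.

Measured so far:
compound 1 `O=C(N/N=C/c1cc(I)cc(I)c1O)c1ccc(I)cc1` – 31800 nM
compound 2 `Cc1ccc(C(=O)NNC(=O)c2cc(I)cc(I)c2O)cc1` – 86400 nM

Compound 2 `Cc1ccc(C(=O)NNC(=O)c2cc(I)cc(I)c2O)cc1` holds the highest of the two numbers in a functional assay on HepG2 cells (Homo sapiens) for cytotoxicity, with a stated time of 24 h (on this read-out lower numbers stand for stronger inhibition and higher numbers for weaker inhibition), where compound 2 gives 86400 nM; compound 1 gives 31800 nM, a lower number, and that gap lies beyond the usual scatter. The two differ in more than one place, so their values are compared only as such.

Compound 3 `O=C(NNC(=O)c1cc(I)cc(I)c1O)c1ccc(I)cc1` carries iodo in place of methyl on an aromatic carbon. Going by the values given here, no single-change step is on hand to size this move. The step from compound 2 to compound 3 is expected to be a 1.6-fold lower number from compound 2 to compound 3 (0.20 log units; within the scatter), a modest drop in the number, loosely leaning on the lower value of compound 1 31800 nM, which also bears a 4-iodophenyl. Compound 3 is thus estimated at 55000 nM, within 25000 nM to 120000 nM.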

Compound 3, half-maximal inhibitory concentration: 25100 nM
For compound 3 the middle estimate is 2.2-fold (0.34 log units) above the measured one, within the range that was stated.
By their numbers in this assay, from the lowest: compounds 3 and 1 (each within the scatter of the next); then compound 2.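

In this assay, going by these compounds alone, the change from 4-methylphenyl to 4-iodophenyl gives a 3.4-fold lower number from compound 2 to compound 3 (0.54 log units; beyond the scatter) and is the first single-change reading at this position on the shared core. Within the data shown here, the earlier pair differed in more than one place, so only this step sizes the iodo for methyl change by itself. No measured property bears on the reason for this shift. Still open, going by these compounds, is how an amine or a carboxylic acid at this position would read, and whether the step carries over to the core of compound 1.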